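The source may hold more compounds than are shown below. What is called first, only, known or untested is meant among the compounds shown, and "the series" means these compounds.

Measured in an ADME assay on TERT-RPE1 cells (Homo sapiens) for cytotoxicity, read by MTT assay, with a stated time of 72 h; on this read-out lower numbers stand for stronger inhibition and higher numbers for weaker inhibition:

- compound 1 `COc1ccc(/C=C2\S/C(=N\c3ccc(Cl)cc3)N(C)C2=O)cc1`: > 100000 nM
- compound 2 `COc1ccc(/C=C2/CN(C)/C(=N/c3ccc(C(F)(F)F)cc3)S2)cc1`: 72000 nM
- compound 3 `COc1ccc(/C=C2/CN(C)/C(=N/c3ccc(Br)cc3)S2)cc1`: 61300 nM

The entry for compound 1 is a limit of the assay and not a number: compound 1 stands at the limit of > 100000 nM in this assay, at which 1 of the 3 values shown sits. Compound 4 `COc1ccc(/C=C2\S/C(=N\c3ccc(C)cc3)N(C)C2=O)cc1` keeps the core of compound 1 and differs from it in one group, (methyl in place of chloro on an aromatic carbon). In words, this is methyl in place of chloro on an aromatic carbon.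

Within the data shown here, only one measured step comes close to this kind of swap: a 1.2-fold lower number from compound 2 to compound 3 (0.07 log units; within the scatter), with bromo in place of trifluoromethyl on an aromatic carbon. That step lies within the scatter, though it was measured on a core that differs from the core of compound 1. It gives only modest guidance, but it offers no reason to expect a step beyond the scatter in this assay, and another limit reading would be no surprise. The expected step is a number no higher from compound 1 to compound 4 (the limit leaves the size open). For compound 4 the estimated value is 100000 nM, with an expected range from 50000 nM to 200000 nM.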

Compound 4, half-maximal inhibitory concentration: > 100000 nM
Compound 4 was reported as a limit; the forecaster's own chance of this, stated with the estimate: 65%; the middle value lies on the limit itself.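

In this assay compound 1 and compound 4 both give a limit and not a number, so no step can be read between them: the limit of > 100000 nM in this assay, at which 2 of the 4 values shown sit. On these data alone, whether methyl and chloro differ at all on the core of compound 1 stays open.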